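Removing the Chain Piperidine from Compound 2

The source may hold more compounds than are shown below. What is called first, only, known or untested is meant among the compounds shown, and "the series" means these compounds.

Among the compounds with values here, the series so far holds two measured compounds in a physicochemical assay for acid dissociation, using potentiometric titration. Compound 1 `Cc1cc(=O)c(O)c(CN2CCCCC2)n1C` gives 10.8, and compound 2 `O=c1cc(CN2CCCCC2)n(CCN2CCCCC2)cc1O` gives 8.83. Compound 2 therefore holds the lower of the two numbers, with a gap to compound 1 that lies beyond the scatter.

The next structure is compound 3 `Cn1cc(O)c(=O)cc1CN1CCCCC1`. The change from compound 2 is hydrogen in place of (piperidin-1-yl)methyl on a saturated chain carbon bound to an aromatic nitrogen.

Within the data shown here, no pair of measured compounds differing in one place is available, so the size of this step cannot be read directly from the data. Compound 1, at 10.8, likewise has no (piperidin-1-yl)methyl on such a chain carbon, which points upward. However, compound 1 also differs from compound 3 elsewhere, so only part of that gap is expected to carry over. A moderate rise in this assay is expected, estimated as a number 0.67 log units higher from compound 2 to compound 3 (beyond the scatter). The estimate for compound 3 is 9.5, with an expected range of 8.8 to 10.4.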

Compound 3, acid dissociation constant: 8.85
Estimate against measurement, compound 3: 0.65 log units above; measured number inside the range.
By their numbers in this assay, from the lowest: compounds 2 and 3 (each within the scatter of the next); then compound 1.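

Hydrogen in place of (piperidin-1-yl)methyl on a saturated chain carbon bound to an aromatic nitrogen gives a number 0.02 log units higher from compound 2 to compound 3 (within the scatter) in this assay, so this exchange leaves no difference that can be separated from the scatter. The group that leaves is sizeable, with 7 heavy atoms, one six-membered non-aromatic ring and 1 hydrogen-bond acceptor, yet compound 2 and compound 3 cannot be told apart by this read-out. Within the data shown here, this is the first step between compounds that differ in one place, so this position now has a direct reading, and no measurement at hand bears on the reason for the result.

Still open, as far as these compounds go, is whether other groups on this saturated chain carbon, such as a primary amine, a carboxylic acid or a longer chain ending in a piperidine, would also stay within the scatter of compound 2 and compound 3. From the compounds shown here alone, one pair sets no pattern, and whether the same exchange would read the same on the core of compound 1 also remains open.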